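Notes on compound 4, a methoxy regioisomer of compound 3

The compounds below may be only part of what the source reports. "The series", "measured", "known", "first", "only" and "open" are said of these compounds alone.

Measured so far:
Compound 1 `O=S(=O)(NCCCNCC1COc2ccccc2O1)c1cc(C(F)(F)F)cc(C(F)(F)F)c1` gives 2700 nM in a functional assay on HPAC cells (Homo sapiens) for inhibition, read by MTT assay, with a stated time of 72 h; a higher number here means a weaker inhibitor of growth, a lower number a stronger inhibitor of growth.
Compound 2 `CN(CCCNS(=O)(=O)c1cc(C(F)(F)F)cc(C(F)(F)F)c1)Cc1ccccc1` gives 30000 nM in this assay.
Compound 3 `COc1ccc(CNCCCNS(=O)(=O)c2cc(C(F)(F)F)cc(C(F)(F)F)c2)cc1` gives 3000 nM in this assay.

Compound 3 sits second highest of the three numbers. Its nearest neighbour is compound 1: the step of a 1.1-fold higher number from compound 1 to compound 3 (0.05 log units; within the scatter) lies within the scatter, so the two are not separable. The step of a 10-fold lower number from compound 2 to compound 3 (1.00 log units; beyond the scatter) is the only one beyond the scatter in the set, and it alters the amine end of the three-carbon chain rather than the aryl group.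

Compound 4 `COc1ccccc1CNCCCNS(=O)(=O)c1cc(C(F)(F)F)cc(C(F)(F)F)c1` differs from compound 3 by 2-methoxyphenyl in place of 4-methoxyphenyl on a saturated chain carbon bound to an amine nitrogen. Going by the values given here, no measured step moves the methoxy group around the ring, so neither step bears on this change directly. The step of a 1.1-fold higher number from compound 1 to compound 3 (0.05 log units; within the scatter) shows that replacing the whole aryl group bound to the chain carbon left the number essentially unchanged, which argues that this part of the molecule tolerates variation. The methoxy shift is a smaller alteration than that, and the step of a 10-fold lower number from compound 2 to compound 3 (1.00 log units; beyond the scatter) does not inform on it.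

For compound 4 a step of a 1.2-fold higher number from compound 3 to compound 4 (0.07 log units; within the scatter) is expected, that is, nothing beyond the scatter. Compound 4 is therefore estimated at 3500 nM, with a range of 1200 nM to 10000 nM.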

Compound 4, concentration for 50% growth inhibition: 2400 nM
Estimate against measurement, compound 4: 1.5-fold (0.16 log units) above; the range from low to high includes it.
By their numbers in this assay, from the lowest: compounds 4, 1 and 3 (each within the scatter of the next); then compound 2.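

In this assay, going by these compounds alone, the step of a 1.3-fold lower number from compound 3 to compound 4 (0.10 log units; within the scatter) is the first direct reading on moving the methoxy group around the ring, and it does not separate 2-methoxyphenyl from 4-methoxyphenyl on the saturated chain carbon bound to the amine nitrogen. The step of a 1.1-fold lower number from compound 1 to compound 4 (0.05 log units; within the scatter) likewise leaves the 2-methoxyphenyl compound inseparable from the 2,3-dihydro-1,4-benzodioxin-2-yl compound, while the step of a 13-fold lower number from compound 2 to compound 4 (1.10 log units; beyond the scatter) shows that the gap to benzyl(methyl)amino, first seen with (4-methoxybenzyl)amino, also holds for (2-methoxybenzyl)amino. No measurement shown here offers an explanation for these numbers.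

Still open is which part of the change from benzyl(methyl)amino carries that gap: the compounds shown do not separate the methyl on the amine from the methoxy on the ring, and a plain benzylamino group would give the direct reading. Also open, on these data alone, is how far the aryl group can vary, for example with a carboxylic acid in place of the methoxy, and whether a longer chain keeps these numbers.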